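The source may report more compounds than this note shows. Statements on the series, on what has been measured and on what is new or still open speak of the compounds shown alone.

In a functional assay on KB 3-1 cells (Homo sapiens) for cytotoxicity, read by MTT assay, with a stated time of 72 h (a higher number here means a weaker inhibitor, a lower number a stronger inhibitor), compound 1 (`O=C1Nc2ccccc2/C1=N/NC(=S)Nc1ccccc1`) gives 3530 nM and compound 2 (`O=C1Nc2ccccc2/C1=N/NC(=S)Nc1ccc(Oc2ccccc2)cc1`) gives 5720 nM. Going by the values given here, compound 2 thus stands within the usual scatter of compound 1, the only other compound measured. Compound 3 (`O=C1Nc2ccccc2/C1=N/NC(=S)Nc1ccc(C(F)(F)F)cc1`) has trifluoromethyl in place of phenoxy on an aromatic carbon. Among the compounds with values here, one measured step bears on this change: a 1.6-fold higher number from compound 1 to compound 2 (0.21 log units; within the scatter), with phenoxy in place of hydrogen on an aromatic carbon. Adding the phenoxy group did not move the number in this assay beyond the scatter, so its removal is not expected to do so either. Within the data shown here, no measured compound carries trifluoromethyl, which leaves the estimate uncertain. The expected change is a 1.6-fold lower number from compound 2 to compound 3 (0.21 log units; within the scatter), and no shift beyond the scatter is anticipated. For compound 3 the estimated value is 3500 nM, with an expected range from 1300 nM to 9000 nM.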

Compound 3, half-maximal inhibitory concentration: 8590 nM
The estimate for compound 3 lay 2.5-fold (0.39 log units) below the measured number; measured number inside the range.
By their numbers in this assay, from the lowest: compounds 1, 2 and 3 (each within the scatter of the next, the first and the last beyond it).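

In this assay, this aromatic carbon now gives its first step beyond the scatter: trifluoromethyl in place of hydrogen brings a 2.4-fold higher number from compound 1 to compound 3 (0.39 log units; beyond the scatter), a modest change. Trifluoromethyl in place of phenoxy brings a 1.5-fold higher number from compound 2 to compound 3 (0.18 log units; within the scatter), so these two groups are not told apart here, although phenoxy has a ring and trifluoromethyl has none. Nothing available explains either step.

From the compounds shown here alone, whether an amine, a carboxylic acid or a methoxy group on this carbon would stay within the scatter of hydrogen remains open. It is also open whether trifluoromethyl would give a similar step on another carbon of the same ring, as the three compounds shown vary only this one place.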